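A few compounds are considered here, and "the series" means these few. Any claim that something is new, unique, unknown or untested is made for them only; others in the source may bear on it.

Compound 2 `Cc1cccc2sc(NC(=O)CCN3CCN(CC4CCCCC4)CC3)nc12` stands lowest of the two numbers in hand: in an assay on membranes from brain for displacement of a labelled ligand from Sigma non-opioid intracellular receptor 1 (Cavia porcellus), read by scintillation counting, with a stated time of 120 min (on this read-out higher numbers stand for weaker inhibition and lower numbers for stronger inhibition), compound 2 gives 35 nM. Compound 1 `Cc1cccc2sc(NC(=O)CCN3CCN(CCN(C)C)CC3)nc12` carries (dimethylamino)methyl where compound 2 carries cyclohexyl; in this assay compound 1 gives 1000 nM. Going by the values given here, the one measured step, cyclohexyl in place of (dimethylamino)methyl on a saturated chain carbon bound to an amine nitrogen in a ring, was large: a 29-fold lower number from compound 1 to compound 2 (1.46 log units; beyond the scatter).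

Compound 3 `Cc1cccc2sc(NC(=O)CCN3CCN(C4CCN(C)CC4)CC3)nc12` differs from compound 2 by 1-methylpiperidin-4-yl in place of cyclohexylmethyl on an amine nitrogen in a ring. This change bears on the same ring-nitrogen substituent, and the entering group again brings a nitrogen, as the group in compound 1 does. Because the measured step of a 29-fold lower number from compound 1 to compound 2 (1.46 log units; beyond the scatter) accompanied the loss of such a nitrogen, a rise in the number is expected for compound 3, though a smaller one, since the six-membered ring is kept. The expected step is a 5.7-fold higher number from compound 2 to compound 3 (0.76 log units; beyond the scatter). Compound 3 is therefore estimated at 200 nM, within 60 nM to 700 nM.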

Compound 3, inhibition constant: 6000 nM
Compound 3: the middle estimate sits 30-fold (1.48 log units) below what was measured; the measured number lies above the stated range.
By their numbers in this assay, from the lowest: compound 2; then compound 1; then compound 3.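

Read in this assay, the exchange of cyclohexylmethyl for 1-methylpiperidin-4-yl gives a 170-fold higher number from compound 2 to compound 3 (2.23 log units; beyond the scatter) and shows that a six-membered non-aromatic ring on this amine nitrogen does not by itself keep the number low. The ring-bearing group also stands worse than the open chain, with a 6.0-fold higher number from compound 1 to compound 3 (0.78 log units; beyond the scatter), so the two nitrogen-bearing groups at this position do not give the same number. Nothing measured here accounts for either step.

The change from compound 2 to compound 3 both adds a ring nitrogen and removes the methylene link, and the compounds shown do not separate the two. Cyclohexyl attached directly to the amine nitrogen, or (1-methylpiperidin-4-yl)methyl in the same place, would tell these two changes apart.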